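A Single Hydroxy Added to an Inactive Benzyl Aniline

This account rests on a few compounds, and the source may have more. Where it says the series, first, only, none or still open, it means among the compounds named here.

In a functional assay on MGC-803 cells (Homo sapiens) for inhibition, read by MTT assay, with a stated time of 48 h (a higher number here means a weaker inhibitor, a lower number a stronger inhibitor), compound 1 `COc1cc(NCc2ccccc2)cc(OC)c1OC` gives > 80000 nM, which is a limit of the assay and not a number. The two other measured compounds return real numbers: compound 2 `COc1ccc(CNc2cc(OC)c(OC)c(OC)c2)cc1[N+](=O)[O-]` gives 19400 nM and compound 3 `C/C=C/C(=O)N(Cc1cc(OC)c(OC)c(OC)c1)c1ccc(OC)c(O)c1` gives 6150 nM. Both differ from compound 1 in more than one place, so neither value isolates a single change.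

Compound 4 `COc1cc(NCc2cccc(O)c2)cc(OC)c1OC` differs from compound 1 by hydroxy in place of hydrogen on an aromatic carbon, reading as phenyl to 3-hydroxyphenyl. Within the data shown here, no measured pair in this assay shows this change alone, so the expectation rests on weak ground. The numbers for compound 2 at 19400 nM show only that a substituted relative of compound 1 can give a number in this assay. The expected at least 1.6-fold lower number from compound 1 to compound 4 (0.20 log units; that floor lies within the scatter) is a small gain in potency, and this assay may again report only a limit. For compound 4 the estimated value is 50000 nM, with an expected range from 20000 nM to 120000 nM.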

Compound 4, half-maximal inhibitory concentration: 57600 nM
For compound 4 the middle estimate is 1.2-fold (0.06 log units) below the measured one; the measured number falls inside the stated range.
By their numbers in this assay, from the lowest: compound 3; then compound 2; then compound 4. At a limit, above all of these: compound 1.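

In this assay compound 4 gives 57600 nM, a real number reached through hydroxy in place of hydrogen on an aromatic carbon alone, which neither compound 2 nor compound 3 could show, as both differ from compound 1 in more than one place. Compound 1 gives > 80000 nM, which is a limit of the assay and not a number. The change can therefore be read only as a floor, an at least 1.3-fold lower number from compound 1 to compound 4 (0.14 log units; that floor lies within the scatter), so the printed step does not establish a change beyond the scatter, and its true size stays unknown: the limit of > 80000 nM in this assay, at which 1 of the 4 values shown sits.

The compounds shown leave open whether an amine or a carboxylic acid in place of this hydroxy would give a similar number. They also leave open how hydroxy would read at another place on the same ring.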